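This account rests on a few compounds, and the source may have more. Where it says the series, first, only, none or still open, it means among the compounds named here.

In a physicochemical assay for solubility, at pH 7.4 (a lower number here means a less soluble compound, a higher number a more soluble compound), compound 1 `Cc1cc(NC(=O)Nc2cccc(C(N)=O)c2)c2ccccc2n1` gives 100 nM, and compound 2 `Cc1cc(NC(=O)Nc2cccc(F)c2)c2ccccc2n1` stands level with it at 100 nM. Compound 3 `Cc1cc(NC(=O)Nc2cc(F)cc(F)c2)c2ccccc2n1` differs from compound 2 by one change, fluoro in place of hydrogen on an aromatic carbon. For the measured compounds named here, only one measured step bears on this, no change at the digits printed from compound 1 to compound 2 (within the scatter), which put fluoro in place of carbamoyl and stayed within the scatter. Going by the values given here, it is an indirect guide, since no measured step adds a fluoro group in place of hydrogen. The expected step is a 1.1-fold lower number from compound 2 to compound 3 (0.05 log units; within the scatter), with no shift beyond the scatter anticipated in this assay. The estimate for compound 3 is 90 nM, with an expected range of 40 nM to 200 nM.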

Compound 3, solubility: 300 nM
Estimate against measurement, compound 3: 3.3-fold (0.52 log units) below; measured number above the stated range.
By their numbers in this assay, from the lowest: compounds 1 and 2 (each within the scatter of the next); then compound 3.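

In this assay, adding a fluoro group meta to a fluoro group already present gives a 3.0-fold higher number from compound 2 to compound 3 (0.48 log units; beyond the scatter), so a change at this place on the aromatic ring can move the number beyond the scatter, which the earlier compounds had not shown. Nothing available accounts for this rise. For the compounds shown here, with only one step of this kind, it stays open whether the rise is specific to fluoro or would also come with a chloro, methyl or methoxy group at this place. Also open, on these data alone, is how an amine or a carboxylic acid there would move the number.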